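The source may report more compounds than this note shows. Statements on the series, on what has been measured and on what is new or still open speak of the compounds shown alone.

Compound 2 `O=C(/C=C/c1ccc(F)cc1)NCCCCNc1ccnc2cc(Cl)ccc12` is tested in an ADME assay on HFF-1 cells (Homo sapiens) for antiproliferative activity, read by sulforhodamine B assay, with a stated time of 2 days; a lower number here means a stronger inhibitor of growth, a higher number a weaker inhibitor of growth. In this assay compound 2 gives > 100000 nM, which is a limit of the assay and not a number. Compound 1 `O=C(/C=C/c1ccccc1)NCCCCNc1ccnc2cc(Cl)ccc12` gives > 100000 nM, also a limit. The step that the two limits leave unreadable from compound 1 to compound 2 is thus of unreadable size, since both values sit at the limit of > 100000 nM in this assay, at which 2 of the 2 values shown sit. Compound 3 `O=C(/C=C/c1cccc([N+](=O)[O-])c1)NCCCCNc1ccnc2cc(Cl)ccc12` differs from compound 2 by 3-nitrophenyl in place of 4-fluorophenyl on a double-bonded chain carbon bound to a double-bonded chain carbon. Within the data shown here, no measured step has a readable size, so no step beyond the scatter is expected, and the expected step is a number no higher from compound 2 to compound 3 (the limit leaves the size open). The estimate for compound 3 is 100000 nM, within 30000 nM to 300000 nM.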

Compound 3, concentration for 50% growth inhibition: > 100000 nM
Compound 3: no number, only a limit; the forecaster's own chance of this, stated with the estimate: 85%; the middle value sits exactly at the limit.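

Among these compounds, compound 1, compound 2 and compound 3 all sit at the same limit in this assay, so no step among them can be read: the limit of > 100000 nM in this assay, at which 3 of the 3 values shown sit. From the compounds shown here alone, how far these three compounds truly differ in this assay stays open.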